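Furan-2-yl in place of 4-chlorophenyl on the shared core

A few compounds are considered here, and "the series" means these few. Any claim that something is new, unique, unknown or untested is made for them only; others in the source may bear on it.

Three compounds sharing one core were measured in a functional assay on OVCAR-3 cells (Homo sapiens) for inhibition, read by sulforhodamine B assay, with a stated time of 48 h; on this read-out higher numbers stand for weaker inhibition of growth and lower numbers for stronger inhibition of growth. Compound 1 `COc1ccc(/C=N/NC(=S)NC(C)(C)[C@H]2CC=C(C)CC2)cc1` gave 21200 nM, compound 2 `CC1=CC[C@H](C(C)(C)NC(=S)N/N=C/c2cccc(Cl)c2)CC1` gave 80500 nM, and compound 3 `CC1=CC[C@H](C(C)(C)NC(=S)N/N=C/c2ccc(Cl)cc2)CC1` gave 26400 nM. Compound 3 stands second highest of the three numbers: it lies within the scatter of compound 1, as a 1.2-fold higher number from compound 1 to compound 3 (0.10 log units; within the scatter) shows, and differs beyond the scatter only from compound 2, as a 3.0-fold lower number from compound 2 to compound 3 (0.48 log units; beyond the scatter) shows. The remaining step, a 3.8-fold higher number from compound 1 to compound 2 (0.58 log units; beyond the scatter), is likewise modest.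

Compound 4 `CC1=CC[C@H](C(C)(C)NC(=S)N/N=C/c2ccco2)CC1` differs from compound 3 by furan-2-yl in place of 4-chlorophenyl on a carbon with a double bond to nitrogen. Going by the values given here, none of the measured steps exchanges the aromatic ring itself; each only moves or swaps a substituent on a phenyl ring, the largest being a 3.8-fold higher number from compound 1 to compound 2 (0.58 log units; beyond the scatter). Among the compounds with values here, the step to compound 4 thus has no direct precedent among them, and no move beyond the scatter in this assay is expected. For compound 4 the expected step is a 1.0-fold lower number from compound 3 to compound 4 (0.01 log units; within the scatter), with room for a modest move either way. Compound 4 is accordingly estimated at 26000 nM, between 9000 nM and 80000 nM.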

Compound 4, concentration for total growth inhibition: 13800 nM
Estimate against measurement, compound 4: 1.9-fold (0.28 log units) above; the measured number falls inside the stated range.
By their numbers in this assay, from the lowest: compounds 4, 1 and 3 (each within the scatter of the next); then compound 2.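

In this assay the aromatic ring itself on the carbon with a double bond to nitrogen proves exchangeable, not only its substituent: furan-2-yl in place of 4-chlorophenyl gives a 1.9-fold lower number from compound 3 to compound 4 (0.28 log units; within the scatter) and furan-2-yl in place of 4-methoxyphenyl gives a 1.5-fold lower number from compound 1 to compound 4 (0.19 log units; within the scatter) and so leaves compound 4 not distinguishable from either. Only furan-2-yl in place of 3-chlorophenyl moves the number beyond the scatter, with a 5.8-fold lower number from compound 2 to compound 4 (0.77 log units; beyond the scatter) as the largest step among these compounds, so compound 2 remains the one that stands apart. Nothing measured here accounts for these steps.

Going by these compounds, whether a thiophen-2-yl or a pyridin-2-yl ring would hold the same level at this place stays open. So does whether an open carbon chain or an amine could stand in for the aromatic ring.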